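Chloro to bromo on the styryl ring: compound 3 to compound 4

The source may hold more compounds than are shown below. What is called first, only, known or untested is meant among the compounds shown, and "the series" means these compounds.

Measured so far in a functional assay on PC-3 cells (Homo sapiens) for antiproliferative activity, read by MTT assay, with a stated time of 12 h; a lower number here means a stronger inhibitor, a higher number a weaker inhibitor:
Compound 1 `COc1ccc2oc(/C=C/c3ccc(OC(F)(F)F)cc3)cc(=O)c2c1` gives only a limit, > 40000 nM, in this assay.
Compound 2 `COc1ccc2c(=O)cc(/C=C/c3ccc(OC(F)(F)F)cc3)oc2c1` also gives only a limit, > 40000 nM, in this assay.
Compound 3 `COc1cc(OC)c2c(=O)cc(/C=C/c3ccc(Cl)cc3)oc2c1` likewise gives only a limit, > 40000 nM, in this assay.

Within the data shown here, compound 3 therefore stands nowhere on a scale of numbers: its value is a limit, and the two other measured compounds sit at the same limit, so that all three measurements of the series so far are limits (the limit of > 40000 nM in this assay, at which 3 of the 3 values shown sit). Among the measured compounds shown here, no pair of measured compounds differs in one place, so no measured step size is available to lean on.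

Compound 4 `COc1cc(OC)c2c(=O)cc(/C=C/c3ccc(Br)cc3)oc2c1` differs from compound 3 by bromo in place of chloro on an aromatic carbon. For the measured compounds named here, with no measured step in hand, the expectation for this change rests on the structural difference alone, which is a single halogen exchanged for another, and no step beyond the usual scatter is expected in this assay. The expected step is a step that the limit leaves unreadable from compound 3 to compound 4, that is, none that the assay would resolve. Compound 4 is expected to return a limit as well, and its estimated value is 60000 nM, with a range from 20000 nM to 200000 nM.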

Compound 4, half-maximal inhibitory concentration: > 40000 nM
Compound 4: no number, only a limit; the forecaster's own chance of this, stated with the estimate: 80%; the middle value is on the limit's open side.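

In this assay compound 4 gives > 40000 nM, which is a limit and not a number. Compound 3 also stands at a limit, so no step can be read between compound 3 and compound 4: the limit of > 40000 nM in this assay, at which 4 of the 4 values shown sit. The compounds shown leave open which change, if any, would give a measurable value in this assay.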